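This account rests on a few compounds, and the source may have more. Where it says the series, first, only, none or still open, it means among the compounds named here.

Compound 1 `O=C(O)c1cc(-c2cccc(COc3ccc4c(=O)n(C5CC5)sc4c3)c2)ccc1Cl` gives 130 nM in an assay on HEK293 cells for positive allosteric modulation of metabotropic glutamate receptor 2 (Rattus norvegicus), read by thallium flux; a lower number here means that less compound is needed, a higher number that more compound is needed for the effect. Compound 3 `CC(C)Cn1sc2cc(OCc3cccc(-c4ccc(Cl)c(C(=O)O)c4)c3)ccc2c1=O` gives 470 nM in this assay. Compound 2 `O=C1c2ccc(OCc3cccc(-c4ccc(C(F)(F)F)cc4F)c3)cc2CN1C1CCCC1` reaches only a limit in this assay, > 5000 nM. Compound 2 therefore stands at the limit of > 5000 nM in this assay, at which 1 of the 3 values shown sits, with no number of its own. Compound 4 `COc1ccc(C(=O)O)cc1-c1cccc(COc2ccc3c(c2)CN(C2CCCC2)C3=O)c1` differs from compound 2 in one place: 5-carboxy-2-methoxyphenyl in place of 2-fluoro-4-(trifluoromethyl)phenyl on an aromatic carbon. Among the measured compounds shown here, no measured step covers this change; the only one, a 3.6-fold higher number from compound 1 to compound 3 (0.56 log units; beyond the scatter), concerns the group on the aromatic nitrogen of a different core. Compounds 1 and 3, both carrying a carboxy group on the outer ring, return numbers rather than limits, so for compound 4 a lower number than the limit of compound 2 is expected, a step of an at least 5.5-fold lower number from compound 2 to compound 4 (0.74 log units; beyond the scatter). Compound 4 is estimated at 900 nM, within 200 nM to 4000 nM.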

Compound 4, half-maximal effective concentration: 80 nM
Estimate against measurement, compound 4: 11-fold (1.05 log units) above, and the stated range ends above it.
By their numbers in this assay, from the lowest: compounds 4 and 1 (each within the scatter of the next); then compound 3. At a limit, above all of these: compound 2.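

On a single shared core, 5-carboxy-2-methoxyphenyl in place of 2-fluoro-4-(trifluoromethyl)phenyl gives an at least 62-fold lower number from compound 2 to compound 4 (1.79 log units; beyond the scatter) in this assay. This is the first pair shown in which only the outer ring changes, and the change at this aromatic carbon takes the series from a limit to a measured number. The step is a bound and not an exact size because compound 2 stands at a limit: the limit of > 5000 nM in this assay, at which 1 of the 4 values shown sits.

The compounds shown do not separate the carboxylic acid from the methoxy group, so which of them carries the step stays open. On these data alone, whether a tetrazole or a primary amide could stand in place of the carboxylic acid also remains open.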